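Amide series: lipophilicity position of compound 4

The source may report more compounds than this note shows. Statements on the series, on what has been measured and on what is new or still open speak of the compounds shown alone.

Compound 1, `Cc1cc(C(=O)NCc2ccccn2)nn1Cc1cc(Cl)ccc1OCc1ccccc1`, gives > 3.7 in a physicochemical assay for lipophilicity, at pH 7.4; a higher number here means a more lipophilic compound, a lower number a more polar compound; this is a limit of the assay, not a number.
Compound 2, `Cc1cc(NC(=O)C2CCCO2)nn1Cc1cc(Cl)ccc1OCc1ccccc1`, gives > 3.7 in this assay; again a limit, not a number.
Compound 3, `Cc1cc(NC(=O)C2CCOC2)nn1Cc1cc(Cl)ccc1OCc1ccccc1`, gives > 3.7 in this assay; also a limit, not a number.

Compound 3 therefore stands only at a limit in this assay, and the two other values shown stand at the same limit: the limit of > 3.7 in this assay, at which 3 of the 3 values shown sit. Among the compounds with values here, none of the measured steps can be read in size. The step that the two limits leave unreadable from compound 1 to compound 2 and the step that the two limits leave unreadable from compound 1 to compound 3 are both unreadable, and so is the step that the two limits leave unreadable from compound 2 to compound 3, which is the only one on the carbonyl carbon itself.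

Compound 4, `Cc1cc(NC(=O)c2ccccc2)nn1Cc1cc(Cl)ccc1OCc1ccccc1`, is the next compound to measure. The change from compound 3 is phenyl in place of oxolan-3-yl on a carbonyl carbon.

Within the data shown here, because the limit of > 3.7 in this assay, at which 3 of the 3 values shown sit, places every measured value at the limit, no measured step gives a size to carry over to this change, and the bearing of the step on the carbonyl carbon from compound 2 to compound 3 stays unknown. For compound 4 the expectation is a value that again reaches the limit, so the estimated step that the limit leaves unreadable from compound 3 to compound 4 is not readable in advance. Compound 4 is estimated at 4.6, within 4 to 5.2.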

Compound 4, distribution coefficient: > 3.7
Compound 4 was reported as a limit; the forecaster's own chance of this, stated with the estimate: 90%; the middle value is on the limit's open side.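

In this assay compound 4 gives > 3.7 as a limit and not a number. Within the data shown here, no step from compound 1, compound 2 or compound 3 to compound 4 can be read in size. The compounds shown leave open how far each of the four lies past this limit, and whether the changes on the carbonyl carbon shift the read-out at all.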